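Methyl for Fluoro on the Fused Ring of Compound 2

This account rests on a few compounds, and the source may have more. Where it says the series, first, only, none or still open, it means among the compounds named here.

For the measured compounds named here, compound 2 `CC(C)C(=O)N1CCC(C[C@@H](c2nc3ccc(F)cc3n2C2CC2)N2C(=O)CN(c3ccc(Oc4ccc(F)cc4)cc3)C2=O)CC1` gives 84.4% in an ADME assay on microsomes from liver (Rattus norvegicus) for metabolic stability, read by LC-MS, with a stated time of 30 min, tested at 1 ug/mL (on this read-out lower numbers stand for a less stable compound and higher numbers for a more stable compound), the highest of the two numbers measured so far; compound 1 `COc1ccc(Oc2ccc(N3CC(=O)N([C@@H](CC4CCN(C(=O)C(C)C)CC4)c4nc5ccc(C)cc5n4C)C3=O)cc2)cc1` gives 12.1% in this assay, a gap beyond the scatter. Compound 3 `Cc1ccc2nc([C@H](CC3CCN(C(=O)C(C)C)CC3)N3C(=O)CN(c4ccc(Oc5ccc(F)cc5)cc4)C3=O)n(C3CC3)c2c1` differs from compound 2 in one place: methyl in place of fluoro on an aromatic carbon. Going by the values given here, no pair of measured compounds isolates this change, and compound 1 differs from compound 2 in several places at once, so the expectation rests on little. A modest fall of a number 16.4 percentage points lower from compound 2 to compound 3 (beyond the scatter) is expected, one that may stay within the scatter. Compound 3 is estimated at 68%, within 38% to 92%.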

Compound 3, percent of the compound remaining: 84.9%
For compound 3 the middle estimate is 16.9 percentage points below the measured one; measured number inside the range.
By their numbers in this assay, from the lowest: compound 1; then compounds 2 and 3 (each within the scatter of the next).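

In this assay, for the compounds shown here, methyl in place of fluoro on this aromatic carbon gives a number 0.5 percentage points higher from compound 2 to compound 3 (within the scatter), the first change here isolated in one place. At this position, the two groups cannot be told apart on this read-out, so a methyl here is compatible with a high number. Nothing available bears on why they read alike. As far as these compounds go, whether an amine, a carboxylic acid or a longer chain at this position would read the same remains open, as does the contribution of each place in which compound 1 differs.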